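From 4-methylpiperazin-1-yl to piperidin-1-yl on a shared core

The source may hold more compounds than are shown below. What is called first, only, known or untested is meant among the compounds shown, and "the series" means these compounds.

Compound 1 `Fc1ccc(N2CCN(c3nc(-n4ccc5ccccc54)c4ccccc4n3)CC2)cc1` gives 50 ug/mL 
Compound 2 `c1ccc2c(c1)ccn2-c1nc(N2CCNCC2)nc2ccccc12` gives 4 ug/mL 
Compound 3 `CN1CCN(c2nc(-n3ccc4ccccc43)c3ccccc3n2)CC1` gives 4.9 ug/mL 

All three values come from a functional assay on KB cells (Homo sapiens) for antiproliferative activity, read by MTT assay (a lower number here means a stronger inhibitor, a higher number a weaker inhibitor), and place compound 3 level with compound 2 within the scatter, while a 10-fold lower number from compound 1 to compound 3 (1.01 log units; beyond the scatter) shows a large gap to the remaining compound. Compound 4 `c1ccc2c(c1)ccn2-c1nc(N2CCCCC2)nc2ccccc12` differs from compound 3 (piperidin-1-yl in place of 4-methylpiperazin-1-yl on an aromatic carbon) with piperidin-1-yl in place of 4-methylpiperazin-1-yl on an aromatic carbon. Among the measured compounds shown here, no measured step covers this exchange directly. The closest evidence concerns the amine nitrogen in the ring: a 1.2-fold higher number from compound 2 to compound 3 (0.09 log units; within the scatter) stays within the scatter, whereas a 13-fold lower number from compound 1 to compound 2 (1.10 log units; beyond the scatter) is large. A step clearly beyond the scatter is therefore not expected in this assay, though a drift toward a higher number is. The expected change is a 1.6-fold higher number from compound 3 to compound 4 (0.21 log units; within the scatter) as estimated here. Compound 4 is estimated at 8 ug/mL with an expected range of 2.5 ug/mL to 25 ug/mL.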

Compound 4, half-maximal inhibitory concentration: 50 ug/mL
Beside the measured number, compound 4's estimate is 6.3-fold (0.80 log units) below it, outside the stated range (above it).
By their numbers in this assay, from the lowest: compounds 2 and 3 (each within the scatter of the next); then compounds 1 and 4 (each within the scatter of the next).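

In this assay, piperidin-1-yl on the aromatic carbon gives a 10-fold higher number from compound 3 to compound 4 (1.01 log units; beyond the scatter) and a 13-fold higher number from compound 2 to compound 4 (1.10 log units; beyond the scatter), so this position does not tolerate every six-membered non-aromatic ring. The earlier close pair changed only hydrogen to methyl on the amine nitrogen, within the scatter, whereas here the loss of that ring nitrogen itself carries a large step. Nothing measured here accounts for this step.

Going by these compounds, it remains open whether morpholin-4-yl, with oxygen at that ring place, would stand with compound 3 or with compound 4. An open-chain amine such as dimethylamino is equally unresolved.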